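Swapping 4-carboxyphenyl for 4-isopropylpiperazin-1-yl

This account rests on a few compounds, and the source may have more. Where it says the series, first, only, none or still open, it means among the compounds named here.

In an ADME assay (liver, Mus musculus) for metabolic stability, using microsomes (on this read-out higher numbers stand for a longer-lived compound and lower numbers for a shorter-lived compound), compound 1 (`CCCc1nc2ccccn2c1C(=O)NCc1ccc(-c2ccccc2)cc1`) gives 0.145 h and compound 2 (`CCc1nc2ccc(Cl)cn2c1C(=O)NCc1ccc(-c2ccccc2Cl)cc1`) gives 0.218 h as a half-life, two values within the usual scatter of each other. Compound 3 (`CCc1nc2cc(Cl)ccn2c1C(=O)NCc1ccc(-c2ccc(C(=O)O)cc2)cc1`) reads > 2 h as a limit of the assay and not a number. Compound 4 (`CCc1nc2cc(Cl)ccn2c1C(=O)NCc1ccc(N2CCN(C(C)C)CC2)cc1`) has 4-isopropylpiperazin-1-yl in place of 4-carboxyphenyl on an aromatic carbon. Neither compound 1 at 0.145 h nor compound 2 at 0.218 h carries the 4-carboxyphenyl, and the expectation rests on those two values alone. The estimated step (an at least 10-fold lower number from compound 3 to compound 4 (1.00 log units; beyond the scatter)) is a fall in half-life beyond the scatter in this assay for this change. For compound 4 the estimated half-life is 0.2 h (expected range 0.08 h to 0.6 h).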

Compound 4, half-life: 0.148 h
Beside the measured number, compound 4's estimate is 1.4-fold (0.13 log units) above it; the range from low to high includes it.
By their numbers in this assay, from the lowest: compounds 1, 4 and 2 (each within the scatter of the next). At a limit, above all of these: compound 3.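

Going by these compounds alone, with the shared core held fixed, 4-isopropylpiperazin-1-yl in place of 4-carboxyphenyl gives an at least 13-fold lower number from compound 3 to compound 4 (1.13 log units; beyond the scatter) in this assay, the only comparison here that differs in one place. The read-out at this position therefore moves beyond the scatter with this change alone, which compounds 1 and 2 could not show. Compound 3 stands at a limit of the assay and not a number: the limit of > 2 h in this assay, at which 1 of the 4 values shown sits.

Open, as far as these compounds go, is whether the difference follows the carboxylic acid or the aromatic ring bearing it. An unsubstituted phenyl, or a carboxylic acid on a saturated ring, at this position on the same core would separate the two.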